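Swapping a Sulfonyl for a Ketone on One Chain Carbon

This account rests on a few compounds, and the source may have more. Where it says the series, first, only, none or still open, it means among the compounds named here.

Compound 1 `CC(=O)/C(=C\c1c(-c2ccccc2)[nH]c2ccccc12)S(=O)(=O)c1ccccc1` and compound 2 `N#C/C(=C\c1c(-c2ccccc2)[nH]c2ccccc12)S(=O)(=O)c1ccccc1` share one core and differ at a single chain carbon. In a functional assay on SK-MEL-28 cells (Homo sapiens) for inhibition, read by sulforhodamine B assay, with a stated time of 48 h (on this read-out lower numbers stand for stronger inhibition of growth and higher numbers for weaker inhibition of growth), compound 1 gives 2000 nM, and compound 2 gives 8300 nM. Within the data shown here, that change was a 4.2-fold higher number from compound 1 to compound 2 (0.62 log units; beyond the scatter), so compound 2 stands with the highest number of the two measured compounds, compound 1 being its only neighbour. Compound 3 `N#C/C(=C\c1c(-c2ccccc2)[nH]c2ccccc12)C(=O)c1ccccc1` is made from compound 2 by a different exchange: benzoyl in place of phenylsulfonyl on a double-bonded chain carbon bound to a double-bonded chain carbon and a triple-bonded carbon. Among the measured compounds shown here, no measured step touches this position; the only measured step concerns the other chain carbon and says nothing about replacing the phenylsulfonyl. The expectation therefore rests on compound 2 alone, and for compound 3 the step of a 1.0-fold lower number from compound 2 to compound 3 (0.02 log units; within the scatter) is expected to stay within the scatter, with a wide range. Compound 3 is thus estimated at 8000 nM, between 2500 nM and 25000 nM.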

Compound 3, concentration for 50% growth inhibition: 12000 nM
Beside the measured number, compound 3's estimate is 1.5-fold (0.18 log units) below it, within the range that was stated.
By their numbers in this assay, from the lowest: compound 1; then compounds 2 and 3 (each within the scatter of the next).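

In this assay, benzoyl in place of phenylsulfonyl on this chain carbon gives a 1.4-fold higher number from compound 2 to compound 3 (0.16 log units; within the scatter), so the two groups cannot be told apart on this read-out. Among these compounds, this is the first reading at this position, and it shows that, with the nitrile on the other chain carbon, the sulfonyl sulfur is not needed to keep the growth inhibition at the level of compound 2: a carbonyl in its place reads the same within the scatter. Nothing at hand accounts for this match.

The compounds shown pair benzoyl only with the nitrile, so whether it would also match phenylsulfonyl alongside the acetyl of compound 1 stays open. Also open, as far as these compounds go, is how this chain carbon would respond to a group carrying no phenyl ring, such as a carboxylic acid or an amine.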